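Swapping methyl for fluoro on the shared core

The source may report more compounds than this note shows. Statements on the series, on what has been measured and on what is new or still open speak of the compounds shown alone.

Measured compounds:
Compound 1 `Cc1ccc2nc(Nc3nc(Nc4ccc(S(C)(=O)=O)cc4)ncc3F)sc2c1`, in a functional assay on MCF7 cells (Homo sapiens) for antiproliferative activity, read by MTT assay, with a stated time of 48 h (on this read-out lower numbers stand for stronger inhibition and higher numbers for weaker inhibition), compound 1 reaches only the limit > 50000 nM.
Compound 2 `CS(=O)(=O)c1ccc(Nc2nccc(Nc3nc4ccc(F)cc4s3)n2)cc1`, in this assay compound 2 reaches only the limit > 60000 nM.
Compound 3 `Cc1cnc(Nc2ccc(S(C)(=O)=O)cc2)nc1Nc1nc2ccc(F)cc2s1`, in this assay compound 3 gives 3260 nM.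

Among the compounds with values here, compound 3 holds the only real number among the three; the other two sit at limits the limit of > 50000 nM in this assay, at which 1 of the 3 values shown sits, and (the limit of > 60000 nM in this assay, at which 1 of the 3 values shown sits). Within the data shown here, the one measured step, an at least 18-fold lower number from compound 2 to compound 3 (1.26 log units; beyond the scatter), shows that the methyl matters. Compound 4 `CS(=O)(=O)c1ccc(Nc2ncc(F)c(Nc3nc4ccc(F)cc4s3)n2)cc1` differs from compound 3 by fluoro in place of methyl on an aromatic carbon. That step removes the group whose addition produced the step from compound 2 to compound 3, and compound 1, which also carries fluoro at that spot, reaches only a limit. A clear loss is therefore expected, with the step of a 7.7-fold higher number from compound 3 to compound 4 (0.88 log units; beyond the scatter), so compound 4 is expected to give 25000 nM, between 5000 nM and 80000 nM.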

Compound 4, half-maximal inhibitory concentration: > 50000 nM
Compound 4 gave a limit, no number (the forecaster's own chance of this, stated with the estimate: 50%); at least 2.0-fold (0.30 log units) between middle value and limit.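

In this assay, fluoro proves no substitute for methyl at this position, giving an at least 15-fold higher number from compound 3 to compound 4 (1.18 log units; beyond the scatter). Compound 4 reaches only a limit, not a number, so that step is a minimum, and compound 4 shares its limit with compound 1: the limit of > 50000 nM in this assay, at which 2 of the 4 values shown sit. The steps to compound 4 from compound 2 and from compound 1 cannot be read, since both ends are limits.

Among the compounds shown, only methyl at this position gives a real number. Going by these compounds, whether an ethyl group, a methoxy group or chlorine there would match or beat it remains open.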